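This account rests on a few compounds, and the source may have more. Where it says the series, first, only, none or still open, it means among the compounds named here.

Of the compounds shown here, three built on one shared core have so far been measured in a physicochemical assay for lipophilicity, in phosphate buffer, measured as octanol-water partition, with a stated time of 24 h; on this read-out lower numbers stand for lower lipophilicity and higher numbers for higher lipophilicity. Compound 1 `O=C(CN1C(=O)c2ccccc2C1=O)NN1C(=O)CSC1c1ccccc1O` gives 1.46. Compound 2 `COc1cc(C2SCC(=O)N2NC(=O)CN2C(=O)c3ccccc3C2=O)ccc1O` gives 1.31, and compound 3 `O=C(CN1C(=O)c2ccccc2C1=O)NN1C(=O)CSC1c1ccc(Cl)cc1` gives 3.21. Among these three numbers compound 1 stands second highest: the nearest of the others lies a number 0.15 log units lower from compound 1 to compound 2 (within the scatter), and the furthest lies a number 1.75 log units higher from compound 1 to compound 3 (beyond the scatter). The remaining pair shows a number 1.90 log units higher from compound 2 to compound 3 (beyond the scatter).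

Compound 4 `CN(C)c1ccc(C2SCC(=O)N2NC(=O)CN2C(=O)c3ccccc3C2=O)cc1` has not yet been measured. It differs from compound 1 in one place: 4-(dimethylamino)phenyl in place of 2-hydroxyphenyl on a saturated ring carbon. Within the data shown here, no measured step exchanges a 2-hydroxyphenyl for a 4-(dimethylamino)phenyl, so the measured steps bear on it only indirectly. The step between two rings that each carry a hydrogen-bond donor stays within the scatter, whereas both steps that exchange such a ring for 4-chlorophenyl are large. The change to compound 4 likewise removes the hydrogen-bond donor, so a step beyond the scatter, in the same direction as the step to compound 3 but probably smaller, is expected in this assay. The step expected is a number 1.14 log units higher from compound 1 to compound 4 (beyond the scatter). Compound 4 is accordingly estimated at 2.6, with a range from 2 to 3.3.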

Compound 4, partition coefficient: 2.84
Compound 4: middle estimate off by 0.24 log units, on the low side, within the range that was stated.
By their numbers in this assay, from the lowest: compounds 2 and 1 (each within the scatter of the next); then compound 4; then compound 3.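

In this assay, the change at this saturated ring carbon now has a second example of a ring without a hydrogen-bond donor replacing one with a donor, and it again gives a large step: a number 1.38 log units higher from compound 1 to compound 4 (beyond the scatter), and a number 1.53 log units higher from compound 2 to compound 4 (beyond the scatter). Among these four compounds, the two whose ring has no hydrogen-bond donor, compound 3 and compound 4, both stand above the two whose ring has one, compound 1 and compound 2, and no compound goes against this. The donor-free rings are not interchangeable, however: with dimethylamino in place of chloro on the aromatic carbon the result is a number 0.37 log units lower from compound 3 to compound 4 (beyond the scatter), a modest step but one beyond the scatter, so the group carried on the ring still matters once the donor is gone.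

On these data alone, whether the pattern would hold for an unsubstituted phenyl, a 4-methoxyphenyl or a ring bearing a carboxylic acid remains open, as does how far it extends to a saturated ring or an alkyl chain at this carbon. Nothing shown here gives a measured reason for any of these steps.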